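Second hydroxy on the hydrazone aryl: compound 3 to compound 4

This account rests on a few compounds, and the source may have more. Where it says the series, first, only, none or still open, it means among the compounds named here.

Three members of the series carry the shared core and differ only in the aryl group on the carbon with a double bond to nitrogen. In a functional assay on A549 cells (Homo sapiens) for cytotoxicity, read by MTT assay, with a stated time of 72 h (on this read-out lower numbers stand for stronger inhibition and higher numbers for weaker inhibition), compound 1 `CN(C)CCn1cnnc1-c1cc(Oc2ccc(NC(=O)N/N=C/c3ccc(O)c(O)c3)cc2F)ccn1` gives only a limit, > 100000 nM, one of the values that sit at the limit of > 100000 nM in this assay, at which 1 of the 3 values shown sits. Compound 2 `CN(C)CCn1cnnc1-c1cc(Oc2ccc(NC(=O)N/N=C/c3ccc(O)cc3)cc2F)ccn1` gives 3560 nM in this assay. Compound 3 `Cc1cc(/C=N/NC(=O)Nc2ccc(Oc3ccnc(-c4nncn4CCN(C)C)c3)c(F)c2)cc(C)c1O` gives 1640 nM in this assay, the lowest of the two numbers shown; its nearest neighbour is compound 2, and the step of a 2.2-fold lower number from compound 2 to compound 3 (0.34 log units; beyond the scatter) is modest. The step of an at least 60-fold lower number from compound 1 to compound 3 (1.78 log units; beyond the scatter) is large.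

Compound 4 `CN(C)CCn1cnnc1-c1cc(Oc2ccc(NC(=O)N/N=C/c3ccc(O)cc3O)cc2F)ccn1` is the next member; the change from compound 3 is 2,4-dihydroxyphenyl in place of 4-hydroxy-3,5-dimethylphenyl on a carbon with a double bond to nitrogen. For the measured compounds named here, two measured steps bear on it. The step of an at least 60-fold lower number from compound 1 to compound 3 (1.78 log units; beyond the scatter) shows that a dihydroxyphenyl group sits at the limit while the dimethylhydroxyphenyl group gives the lowest number, and the step of a 2.2-fold lower number from compound 2 to compound 3 (0.34 log units; beyond the scatter) shows the methyl groups lower the number modestly. Compound 4 both loses the methyl groups and gains a second hydroxy, so a higher number is expected in this assay, with the step of a 7.3-fold higher number from compound 3 to compound 4 (0.86 log units; beyond the scatter) as the estimate; compound 1 gives only a limit, so a limit for compound 4 cannot be excluded. For compound 4 the expected value in this assay is 12000 nM, in the range 2500 nM to 80000 nM.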

Compound 4, half-maximal inhibitory concentration: 12700 nM
Compound 4: middle estimate off by 1.1-fold (0.02 log units), on the low side; measured number inside the range.
By their numbers in this assay, from the lowest: compound 3; then compound 2; then compound 4. At a limit, above all of these: compound 1.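

In this assay, a second hydroxy on the aryl group is not always as damaging as the earlier compounds suggested, yet it still carries a cost against the single hydroxy, a 3.6-fold higher number from compound 2 to compound 4 (0.55 log units; beyond the scatter), and a larger one against the methyl-bearing group, a 7.7-fold higher number from compound 3 to compound 4 (0.89 log units; beyond the scatter), so 4-hydroxy-3,5-dimethylphenyl keeps the lowest number among the aryl groups shown. The new information is that the two dihydroxyphenyl groups are not interchangeable on the carbon with a double bond to nitrogen: the 2,4-dihydroxyphenyl group in place of the 3,4-dihydroxyphenyl group gives an at least 7.8-fold lower number from compound 1 to compound 4 (0.89 log units; beyond the scatter), so the pattern of the hydroxy groups matters and not merely their number. The size of that step is only a bound, since compound 1 is a limit and not a number: the limit of > 100000 nM in this assay, at which 1 of the 4 values shown sits.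

The compounds shown leave open whether a methoxy group in place of the second hydroxy would keep the number of compound 2 or lower it. They also leave open whether the two methyl groups of compound 3 would still help on an aryl group without any hydroxy, such as 3,5-dimethylphenyl.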